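A few compounds are considered here, and "the series" means these few. Any claim that something is new, unique, unknown or untested is made for them only; others in the source may bear on it.

Going by the values given here, compound 1 `C[C@@H](NC(=O)Nc1ccccc1F)c1ccccc1` and compound 2 `C[C@@H](NC(=O)Nc1cccc(F)c1)c1ccccc1` are the two compounds measured so far in an ADME assay on the whole organism with Oryza sativa as the target, tested at 1 uM; on this read-out lower numbers stand for a stronger effect and higher numbers for a weaker effect at the one concentration tested. Compound 1 gives 95% in this assay, and compound 2 gives 95%: the two values are level at the digits shown, within the scatter. Compound 3 `C[C@@H](NC(=O)Nc1cc(F)ccc1F)c1ccccc1` has not yet been measured. It differs from compound 2 by fluoro in place of hydrogen on an aromatic carbon. Among the compounds with values here, no step between measured compounds is available, so the expectation rests on compound 2 alone, and a step beyond the scatter is not expected, the expected change being a number 2 percentage points lower from compound 2 to compound 3 (within the scatter). For compound 3 the estimated value in this assay is 93%, with a range from 80% to 100%.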

Compound 3, a percentage reported as activity, at one concentration (the size of the read-out at that concentration, not a potency): 100%
For compound 3 the middle estimate is 7 percentage points below the measured one; measured number inside the range.
By their numbers in this assay, from the lowest: compounds 1, 2 and 3 (each within the scatter of the next).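

In this assay fluoro in place of hydrogen on an aromatic carbon, ortho to a large group and para to a fluoro group, gives a number 5 percentage points higher from compound 2 to compound 3 (within the scatter) and, as the same kind of swap starting from the other single-fluoro compound, a number 5 percentage points higher from compound 1 to compound 3 (within the scatter). A second fluoro on this ring therefore leaves the read-out within the scatter of both single-fluoro compounds. Nothing measured here explains this result. From the compounds shown here alone, what stays open is whether a larger group at this position, such as chloro, methoxy or an amine, would shift the read-out beyond the scatter.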